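Removing one chloro group from compound 2

This account rests on a few compounds, and the source may have more. Where it says the series, first, only, none or still open, it means among the compounds named here.

Two compounds in this set share a core, and neither gives a number in an assay on cells for antagonist activity at P2X purinoceptor 2 (Homo sapiens), read by fluorescence and calcium flux, with a stated time of 30 min; a lower number here means a stronger inhibitor, a higher number a weaker inhibitor. Compound 1 `O=C(Nc1cccc(C(F)(F)F)c1)c1cc(Cl)ccc1O` carries a trifluoromethyl group on one of its rings. In this assay compound 1 gives > 10000 nM, which is a limit of the assay rather than a measured value. Compound 2 `O=C(Nc1cc(Cl)cc(Cl)c1)c1cc(Cl)ccc1O` carries two chloro groups instead. In this assay compound 2 gives > 10000 nM, again a limit and not a number. Within the data shown here, compound 2 therefore has no definite place on a scale: it sits at the limit of > 10000 nM in this assay, at which 2 of the 2 values shown sit, and the one other value shown sits there as well, so no step between measured compounds can be counted.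

Compound 3 `O=C(Nc1cccc(Cl)c1)c1cc(Cl)ccc1O` differs from compound 2 in one place: hydrogen in place of chloro on an aromatic carbon. Among the measured compounds shown here, with compound 2 offering only a limit, there is no measured pair against which this change can be sized. The expected step that the limit leaves unreadable from compound 2 to compound 3 is none beyond the scatter, with inhibition staying weak. Compound 3 is therefore expected to give about 20000 nM in this assay, within a range from 5000 nM to 80000 nM, and most likely the assay will again report only a limit.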

Compound 3, half-maximal inhibitory concentration: > 10000 nM
Compound 3: no number, only a limit; the forecaster's own chance of this, stated with the estimate: 75%; the middle value is on the limit's open side.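

In this assay compound 3 gives > 10000 nM as a limit of the assay and not a number. Among these compounds, no step can therefore be read from compound 1 or compound 2 to compound 3: the limit of > 10000 nM in this assay, at which 3 of the 3 values shown sit. The compounds shown leave open how far each lies from that limit, and whether these changes on the aromatic ring alter inhibition at all.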